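Three aryl piperazines and the step to a methyl analogue

A few compounds are considered here, and "the series" means these few. Any claim that something is new, unique, unknown or untested is made for them only; others in the source may bear on it.

Three compounds share a succinimide-bearing amide on an aryl piperazine. Compound 1 `CC(C(=O)N1CCN(c2ccccc2C(F)(F)F)CC1)N1C(=O)CCC1=O` gives 25% in a functional assay on the whole organism (strain Swiss) with Mus musculus as the target, in the maximal electroshock model, with a stated time of 1 h, at a dose of 100 mg/kg by the intraperitoneal route (a lower number here means a weaker effect, a higher number a stronger effect of the compound at the dose given), compound 2 `COCC(C(=O)N1CCN(c2cccc(C(F)(F)F)c2)CC1)N1C(=O)CCC1=O` gives 50%, and compound 3 `CC(C(=O)N1CCN(c2ccc(F)cc2)CC1)N1C(=O)CCC1=O` gives 0%, the lowest of the three numbers; its gap to compound 1 and to compound 2 lies beyond the scatter in each case. Compound 4 `Cc1cccc(N2CCN(C(=O)C(C)N3C(=O)CCC3=O)CC2)c1` has not been measured. It differs from compound 3 in one place: 3-methylphenyl in place of 4-fluorophenyl on an amine nitrogen in a ring. Among the measured compounds shown here, no step between measured compounds isolates this change. Given that compound 1 reaches 25% and compound 2 reaches 50%, a rise beyond the scatter is expected, with the step from compound 3 to compound 4 estimated at a number 25 percentage points higher from compound 3 to compound 4 (beyond the scatter). Compound 4 is expected to give 25%, within 0% to 50%.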

Compound 4, a percentage reported as activity, at one dose (the size of the read-out at that dose, not a potency): 0%
For compound 4 the middle estimate is 25 percentage points above the measured one, within the range that was stated.
By their numbers in this assay, from the lowest: compounds 3 and 4 (each within the scatter of the next); then compound 1; then compound 2.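

In this assay, among the compounds shown here, the exchange of 4-fluorophenyl for 3-methylphenyl on an amine nitrogen in a ring shows no change at the digits printed from compound 3 to compound 4 (within the scatter), the first step that isolates a change at this position. At this dose, these two groups, with equal heavy-atom counts, cannot be told apart. Nothing given here offers an explanation for this result. Going by these compounds, it remains open whether a chlorine or a methoxy group on this phenyl ring would lift the read-out above that of compound 4 at 0%.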